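The compounds below may be only part of what the source reports. "The series", "measured", "known", "first", "only" and "open" are said of these compounds alone.

Compound 1 `CCOC(=O)c1c(-c2cccc(OCC)c2)[nH]c2cc(OC)ccc2c1=O`: > 21500 nM
Compound 2 `CCCCOc1cccc(-c2[nH]c3cc(OC)ccc3c(=O)c2C(=O)OCC)c1`: > 21500 nM

In an ADME assay on BJ cells (Homo sapiens) for cytotoxicity, read by luminescence, with a stated time of 72 h (a higher number here means that more compound is needed for the effect, a lower number that less compound is needed), compound 1 gives > 21500 nM, which is a limit of the assay rather than a number. Compound 2 gives > 21500 nM in this assay, again a limit. Compound 1 therefore stands only at a limit, and both values shown sit at it: the limit of > 21500 nM in this assay, at which 2 of the 2 values shown sit. For the measured compounds named here, the single measured step, a step that the two limits leave unreadable from compound 1 to compound 2, has a size that cannot be read. Compound 3 `CCOC(=O)c1c(-c2cccc(OCc3ccccc3)c2)[nH]c2cc(OC)ccc2c1=O` differs from compound 1 by phenyl in place of methyl on a saturated chain carbon bound to an oxygen on an aromatic ring. Going by the values given here, the only comparison on hand, which also alters the chain on the aromatic oxygen of compound 1, is unreadable, so no step beyond the scatter is expected in this assay from this change either. Compound 3 is therefore expected to remain at the limit, with an estimated step that the limit leaves unreadable from compound 1 to compound 3 and an estimate of 30000 nM in the range 12000 nM to 80000 nM.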

Compound 3, half-maximal effective concentration: > 21500 nM
Compound 3: only a limit was reported (the forecaster's own chance of this, stated with the estimate: 75%); the middle value is on the limit's open side.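

In this assay compound 3 gives > 21500 nM, a limit of the assay. No step from compound 1 or compound 2 to compound 3 can be read: the limit of > 21500 nM in this assay, at which 3 of the 3 values shown sit.

The compounds shown leave open what concentration of any of them produces the effect in this assay, and whether ethoxy to benzyloxy changes it.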